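The source may hold more compounds than are shown below. What is called first, only, known or untested is meant among the compounds shown, and "the series" means these compounds.

Compound 1 `COc1cc(-c2cc(/C=C/C(=O)c3ccc(N)cc3)[nH]n2)cc(OC)c1OC` and compound 2 `COc1cc(-c2cc(/C=C/C(=O)c3ccc(Cl)c(Cl)c3)[nH]n2)cc(OC)c1OC` share one core and differ only in the ring attached to the carbonyl carbon. In a functional assay on SR cells (Homo sapiens) for cytotoxicity, read by sulforhodamine B assay, with a stated time of 48 h, tested at 0.1 uM (a higher number here means a weaker effect of the compound at the concentration tested, a lower number a stronger effect), compound 1 gives 87%, while compound 2 gives 89%. Compound 1 thus stands at one end of the two numbers, but the step of a number 2 percentage points higher from compound 1 to compound 2 (within the scatter) does not separate the two compounds in any meaningful way.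

Compound 3 `COc1cc(-c2cc(/C=C/C(=O)c3ccc(F)c(F)c3)[nH]n2)cc(OC)c1OC` has not yet been measured in this assay. Its structure differs from compound 1 as follows: 3,4-difluorophenyl in place of 4-aminophenyl on a carbonyl carbon. Going by the values given here, the only measured step that bears on this change is the exchange of the same aminophenyl group for a dihalogenated phenyl, a number 2 percentage points higher from compound 1 to compound 2 (within the scatter), which stayed within the scatter. On that basis no step beyond the scatter is expected for compound 3, that is a number 1 percentage points higher from compound 1 to compound 3 (within the scatter). Compound 3 is therefore estimated to give about 88% in this assay, with a likely range from 76% to 98%.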

Compound 3, a percentage reported as activity, at one concentration (the size of the read-out at that concentration, not a potency): 106%
Estimate against measurement, compound 3: 18 percentage points below, outside the stated range (above it).
By their numbers in this assay, from the lowest: compounds 1 and 2 (each within the scatter of the next); then compound 3.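

The ring on the carbonyl carbon is not indifferent in this assay: 3,4-difluorophenyl gives a number 19 percentage points higher from compound 1 to compound 3 (beyond the scatter) and a number 17 percentage points higher from compound 2 to compound 3 (beyond the scatter), whereas the earlier exchange gave only a number 2 percentage points higher from compound 1 to compound 2 (within the scatter). A higher number means a weaker effect here, so compound 3 has the weakest effect of the three at this concentration, and 3,4-difluorophenyl does not read like 3,4-dichlorophenyl even though the two rings differ only in their halogen. Nothing available explains this difference.

The compounds shown leave open how an unsubstituted phenyl ring or a ring carrying methoxy groups would read on the same carbonyl carbon. With a read-out at a single concentration, they also leave open how the three compounds compare in potency.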